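The source may hold more compounds than are shown below. What is called first, only, known or untested is meant among the compounds shown, and "the series" means these compounds.

Compound 1 `O=c1[nH]c(=O)n(Cc2ccccc2)cc1Nc1ccccc1` has no result in an ADME assay on Akata cells (Homo sapiens) for cytotoxicity, read by XTT assay; a lower number here means that less compound is tolerated, a higher number that more compound is tolerated: for compound 1 the entry reads "not determined" (no result reported). Compound 2 `Cc1cc(C)cc(Cn2cc(Nc3ccccc3)c(=O)[nH]c2=O)c1` gives 96200 nM in this assay, and compound 3 `Cc1ccc(Nc2cn(Cc3ccc(Cl)cc3Cl)c(=O)[nH]c2=O)cc1` gives 92300 nM; these two numbers sit within the scatter of each other, so no order between them can be read from them. Compound 4 `O=c1[nH]c(=O)n(Cc2ccc(Cl)cc2Cl)cc1NCc1ccccc1` is built from compound 3 by one change: benzyl in place of 4-methylphenyl on a nitrogen on an aromatic ring, that is, the (4-methylphenyl)amino becomes a benzylamino. Going by the values given here, no measured pair shows this change directly. With both measured compounds giving numbers of the same size, the author expects compound 4 to stay close to compound 3, with a step of a 1.0-fold lower number from compound 3 to compound 4 (0.01 log units; within the scatter) that is not expected to go beyond the scatter. The estimate for compound 4 in this assay is 90000 nM, with a range from 40000 nM to 200000 nM.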

Compound 4, half-maximal cytotoxic concentration: 96300 nM
Beside the measured number, compound 4's estimate is 1.1-fold (0.03 log units) below it; measured number inside the range.
By their numbers in this assay, from the lowest: compounds 3, 2 and 4 (each within the scatter of the next).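

In this assay the first pair differing in one place gives a 1.0-fold higher number from compound 3 to compound 4 (0.02 log units; within the scatter) and so shows that, on this nitrogen, benzyl in place of 4-methylphenyl, with the same atoms joined differently, leaves no readable change. That holds for this single pair only, with the rest of compound 3 and compound 4 the same. Nothing given here bears on why the number holds. Open, going by these compounds, is whether a longer chain ending in an amine or a carboxylic acid on this nitrogen would move the number beyond the scatter.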